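Halogen exchange on the pendant phenyl of compound 2

This account rests on a few compounds, and the source may have more. Where it says the series, first, only, none or still open, it means among the compounds named here.

Compound 1 `COc1ccc(-c2csc3nc(-c4cc(F)c(Cl)cc4Cl)nn23)cc1` and compound 2 `Fc1cc(-c2nc3scc(-c4ccc(Cl)cc4)n3n2)c(Cl)cc1Cl` share one core. In a functional assay on the whole organism (strain Wister albino) for inhibition, with Rattus norvegicus as the target, read by paw edema, with stated times of 30 min and 3 h, at a dose of 50 mg/kg by the oral route (a lower number here means less inhibition, a higher number more inhibition at the dose given (going by the name of the read-out)), compound 1 gives 40.6% and compound 2 gives 42.2%; the step of a number 1.6 percentage points higher from compound 1 to compound 2 (within the scatter) leaves the two values within the scatter of each other, so no order between them can be read. Compound 3 `Fc1cc(-c2nc3scc(-c4ccc(Br)cc4)n3n2)c(Cl)cc1Cl` differs from compound 2 by bromo in place of chloro on an aromatic carbon. Going by the values given here, no measured step covers a bromo-for-chloro exchange, and the single step that is measured changed nothing beyond the scatter. For compound 3 a step of a number 0.8 percentage points higher from compound 2 to compound 3 (within the scatter) is therefore expected, none beyond the scatter. The estimate for compound 3 is 43%, with a range from 33% to 53%.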

Compound 3, a percentage reported as inhibition, in the whole organism at one dose (the size of the read-out at that dose, not a potency): 25%
Estimate against measurement, compound 3: 18 percentage points above; the whole stated range lies above it.
By their numbers in this assay, from the lowest: compound 3; then compounds 1 and 2 (each within the scatter of the next).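

In this assay this position on the six-membered aromatic ring responds to the halogen: 4-chlorophenyl to 4-bromophenyl gives a step beyond the scatter (a number 17.2 percentage points lower from compound 2 to compound 3 (beyond the scatter)). Bromo in place of methoxy at the same place also gives a step beyond the scatter (a number 15.6 percentage points lower from compound 1 to compound 3 (beyond the scatter)), so bromo stands apart from both groups, whereas the earlier chloro-for-methoxy step did not separate them. No measured evidence bears on the reason for this drop.

Open, from the compounds shown here alone, is whether the loss is particular to bromo or extends to other groups here, such as iodo, an amine or a carboxylic acid.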